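This account rests on a few compounds, and the source may have more. Where it says the series, first, only, none or still open, it means among the compounds named here.

Series notes. Compound 1 `O=C(NC/C=C1\CCCc2cnn(Cc3ccc(Cl)cc3Cl)c21)NS(=O)(=O)c1cccs1` is the urea member of the set; in a functional assay on CHO-K1 cells for antagonist activity at prostaglandin E2 receptor EP3 subtype (Homo sapiens), read by TR-FRET and cAMP accumulation, with a stated time of 30 min (a higher number here means a weaker inhibitor, a lower number a stronger inhibitor), compound 1 gives 28 nM. Compound 2 `O=C(NS(=O)(=O)c1cc(Cl)c(Cl)s1)OC/C=C1\CCCc2cnn(Cc3ccc(Cl)cc3Cl)c21` carries a carbamate and a (4,5-dichlorothiophen-2-yl)sulfonyl group; in this assay compound 2 gives 5 nM. Of the two numbers in hand, compound 2 stands lowest, with compound 1 as its nearest neighbour at the higher number, a gap beyond the usual scatter. Within the data shown here, because the two compounds differ in more than one place, the pair shows only this difference in values and isolates no single step.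

Compound 3 `O=C(NS(=O)(=O)c1ccc(Cl)cc1)OC/C=C1\CCCc2cnn(Cc3ccc(Cl)cc3Cl)c21` keeps the carbamate and the shared core of compound 2 and alters only the sulfonyl substituent: 4-chlorophenyl in place of 4,5-dichlorothiophen-2-yl on a sulfonyl sulfur. Among the measured compounds shown here, no measured pair isolates this change, so the expectation rests on compound 2 alone and on the counted difference. In this assay the step is expected to be small and toward a higher number, a 2.4-fold higher number from compound 2 to compound 3 (0.38 log units; beyond the scatter), likely close to the scatter. For compound 3 the estimate in this assay is 12 nM, within a range of 4 nM to 40 nM.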

Compound 3, half-maximal inhibitory concentration: 92 nM
Estimate against measurement, compound 3: 7.7-fold (0.88 log units) below, outside the stated range (above it).
By their numbers in this assay, from the lowest: compound 2; then compound 1; then compound 3.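

With the carbamate and the shared core held fixed, 4-chlorophenyl in place of 4,5-dichlorothiophen-2-yl on a sulfonyl sulfur gives an 18-fold higher number from compound 2 to compound 3 (1.26 log units; beyond the scatter) in this assay, a large step and the first in the series to isolate a single change. The position is therefore sensitive to which aryl group it carries, even though the leaving and entering groups have the same heavy-atom count; they differ in ring size, in ring atoms, in the number of chlorines and in the hydrogen-bond acceptor count. No supporting measurement bears on this result, so the step gives the size of the change and no reason for it.

The compounds shown leave open whether the difference follows the five-membered aromatic ring or its chlorines, which a 5-chlorothiophen-2-yl or a 3,4-dichlorophenyl on the same sulfonyl sulfur would help to separate. Also open, on these data alone, is whether a step of this size would recur with the urea of compound 1 in place of the carbamate, and how a non-aromatic group such as cyclopropyl would read at this position.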